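Urea series: aryl change from compound 2 to compound 3

The compounds below may be only part of what the source reports. "The series", "measured", "known", "first", "only" and "open" are said of these compounds alone.

Compound 1 `CC(C)c1cccc(C(C)C)c1NC(=O)NCC1(c2cccs2)CCCC1` gives 12 nM in an assay on microsomes from intestine for inhibition of acyl-CoA:cholesterol acyltransferase (Oryctolagus cuniculus); on this read-out higher numbers stand for weaker inhibition and lower numbers for stronger inhibition. Compound 2 `Cc1cccc(NC(=O)NCC2(c3ccccc3)CCCCC2)c1` gives 2800 nM in this assay, the higher of the two numbers and well apart from compound 1. Compound 3 `O=C(NCC1(c2ccccc2)CCCCC1)Nc1cccc(Cl)c1Cl` has not yet been measured in this assay. It differs from compound 2 as follows: 2,3-dichlorophenyl in place of 3-methylphenyl on an amide-type nitrogen. Going by the values given here, no measured pair shows this change, so the step from compound 2 to compound 3 is expected to be modest, toward a lower number in this assay, and is estimated as a 1.9-fold lower number from compound 2 to compound 3 (0.27 log units; within the scatter). Compound 3 is expected to give about 1500 nM in this assay, within 300 nM to 6000 nM.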

Compound 3, half-maximal inhibitory concentration: 1300 nM
Compound 3: the middle estimate sits 1.2-fold (0.06 log units) above what was measured; measured number inside the range.
By their numbers in this assay, from the lowest: compound 1; then compound 3; then compound 2.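

The aryl group on the amide-type nitrogen now has its first readable step: in this assay, 2,3-dichlorophenyl in place of 3-methylphenyl gives a 2.2-fold lower number from compound 2 to compound 3 (0.33 log units; beyond the scatter). The number at this position therefore responds to the aryl group, though only modestly for this change. Nothing on hand bears on why the step occurs.

Compound 1 differs from compound 3 in more than one place, so the share of its aryl group in its value stays unassigned. Also open, from the compounds shown here alone, is how a 3-chlorophenyl or an aminophenyl on this nitrogen would compare.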